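N-Demethylation of the weaker diastereomer

The source may hold more compounds than are shown below. What is called first, only, known or untested is meant among the compounds shown, and "the series" means these compounds.

Measured compounds:
compound 1, `CN1CCC[C@@H]1[C@H]1COc2ccc(O)cc2O1` — 3500 nM
compound 2, `CN1CCC[C@H]1[C@H]1COc2ccc(O)cc2O1` — 421 nM

Two diastereomers share the same core and are measured in an assay on Cerebral cortex (strain Sprague-Dawley) for displacement of a labelled ligand from Neuronal acetylcholine receptor; alpha4/beta2 (Rattus norvegicus); on this read-out lower numbers stand for stronger inhibition and higher numbers for weaker inhibition. In this assay compound 1 gives 3500 nM and compound 2 gives 421 nM. Within the data shown here, the only step among them, an 8.3-fold lower number from compound 1 to compound 2 (0.92 log units; beyond the scatter), rests on (the fact that compounds 1 and 2 differ only in the configuration as drawn). Compound 1 therefore stands at the higher of the two numbers, the weaker end of what has been measured.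

Compound 3, `Oc1ccc2c(c1)O[C@@H]([C@H]1CCCN1)CO2`, is derived from compound 1 by hydrogen in place of methyl on an amine nitrogen in a ring. Among the measured compounds shown here, no measured step follows a change at that nitrogen; the one measured step concerns configuration only and does not bear on this change. For that reason no step beyond the scatter is expected in this assay in either direction, and the estimate is correspondingly wide.

For compound 3 in this assay the estimated result is 3500 nM, within the range 900 nM to 14000 nM. The step this implies, no change at the digits printed from compound 1 to compound 3 (within the scatter), is expected to stay within the usual scatter.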

Compound 3, inhibition constant: 18000 nM
Beside the measured number, compound 3's estimate is 5.1-fold (0.71 log units) below it; measured number above the stated range.
By their numbers in this assay, from the lowest: compound 2; then compound 1; then compound 3.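

In this assay, putting hydrogen in place of methyl on the amine nitrogen of the five-membered ring gives a 5.1-fold higher number from compound 1 to compound 3 (0.71 log units; beyond the scatter), so the change moves the result towards weaker inhibition. The earlier step concerned configuration alone, whereas this one shows that the number also responds to the substituent on this nitrogen, even though the change removes only one heavy atom, a carbon, and that atom sits on a ring nitrogen next to the ring atom that bears a large group. Nothing in the available evidence bears on this change at the nitrogen, so the data give no account of the loss.

The compounds shown leave open whether the same replacement would move the number in the same direction and by a similar size in the configuration of compound 2, since this step has been read only in the configuration of compound 1. They also leave open how the result would respond to an ethyl group or a longer chain on this nitrogen. Methyl and hydrogen are the only two substituents shown there.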